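The source may hold more compounds than are shown below. What is called first, only, known or untested is meant among the compounds shown, and "the series" means these compounds.

Compound 1 `CNC(=O)c1sc(N2CC3CC2(CNC(=O)c2c[nH]c4ncc(C(F)(F)F)cc24)C3)nc1C(F)(F)F` holds a trifluoromethyl group on a fused ring of its core. In an ADME assay on microsomes from liver (Homo sapiens) for metabolic stability (on this read-out lower numbers stand for slow clearance and higher numbers for fast clearance), compound 1 gives 130 mL.min-1.g-1, which is the only full number among the two results shown, so compound 1 stands as the more rapidly cleared of the pair. Compound 2 `C[C@@H]1CN(c2cnc(Nc3cc(F)c(OCC4CC4)c(F)c3)nc2NC2CCOCC2)CCN1` belongs to a quite different structural family. In this assay compound 2 gives only a limit, < 3 mL.min-1.g-1, as described by the limit of < 3 mL.min-1.g-1 in this assay, at which 1 of the 2 values shown sits. Compound 3 `CNC(=O)c1sc(N2CC3CC2(CNC(=O)c2c[nH]c4ncc(Cl)cc24)C3)nc1C(F)(F)F` differs from compound 1 in a single place: chloro in place of trifluoromethyl on an aromatic carbon. Among the measured compounds shown here, no measured pair shows what such a swap does here, so the step of a 1.1-fold higher number from compound 1 to compound 3 (0.03 log units; within the scatter) is expected to stay within the usual scatter of this assay, with no clear direction either way. Compound 3 is therefore estimated at about 140 mL.min-1.g-1, in the range from 65 mL.min-1.g-1 to 300 mL.min-1.g-1.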

Compound 3, intrinsic clearance in microsomes: > 300 mL.min-1.g-1
Compound 3 ended at the assay's limit (the forecaster's own chance of this, stated with the estimate: 3%); at least 2.1-fold (0.33 log units) between middle value and limit.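

Among the compounds shown here, replacing trifluoromethyl with chloro on this aromatic carbon of the six-membered aromatic ring with 1 nitrogen gives an at least 2.3-fold higher number from compound 1 to compound 3 (0.36 log units; beyond the scatter) in this assay and is the first single change here with a readable effect. Going by these compounds, compound 3 gives > 300 mL.min-1.g-1 as a limit and not a number, so the full size of the step stays unknown. Even so, clearance in this series clearly responds to the group on this carbon, something the earlier compounds, with no pair differing in one place, could not show.

A single swap cannot separate the effect of losing trifluoromethyl from that of gaining chloro, and it gives no reason for the change. On these data alone, how a nitrile, a methyl group or a plain hydrogen on this carbon would read stays open, as does whether the same swap would act alike on a different core.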